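A few compounds are considered here, and "the series" means these few. Any claim that something is new, unique, unknown or untested is made for them only; others in the source may bear on it.

Three compounds of the series have been run in an ADME assay on HEK293 cells (Homo sapiens) for cytotoxicity, read by CellTiter-Glo and resazurin assay, with a stated time of 72 h; a higher number here means that more compound is needed for the effect, a lower number that less compound is needed. Compound 1 `CCOC(=O)CCCCCOc1cccc(CN(C(=O)c2ccc(-c3ccoc3)cc2)C(C)C)c1` gives only a limit there, > 26000 nM. Compound 2 `CCOC(=O)CCCCCOc1cccc(CN(C(=O)c2ccc(-c3cccc(OC)c3)cc2)C(C)C)c1` also gives only a limit, > 21000 nM. Compound 3 `CCOC(=O)CCCCCOc1cccc(CN(C(=O)c2ccc(-c3ccc4[nH]ccc4c3)cc2)C(C)C)c1` likewise gives only a limit, > 26000 nM. Compound 3 thus stands at the limit of this assay together with the other two, as shown by the limit of > 26000 nM in this assay, at which 2 of the 3 values shown sit, and (the limit of > 21000 nM in this assay, at which 1 of the 3 values shown sits). The steps a step that the two limits leave unreadable from compound 1 to compound 2, a step that the two limits leave unreadable from compound 1 to compound 3 and a step that the two limits leave unreadable from compound 2 to compound 3 therefore carry no readable size, since both ends of each sit at a limit.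

Compound 4 `CCOC(=O)CCCCCOc1cccc(CN(C(=O)c2ccc(-c3cccc(Br)c3)cc2)C(C)C)c1` has not yet been measured. It differs from compound 3 in one place: 3-bromophenyl in place of 1H-indol-5-yl on an aromatic carbon. For the measured compounds named here, no measured step bears on this change with a readable size, and no compound of the series has so far given a number in this assay rather than a limit. Compound 4 is therefore expected to give a limit again in this assay, and the step that the limit leaves unreadable from compound 3 to compound 4 is expected to be one without readable direction. For compound 4 the estimate is 30000 nM, with a range from 10000 nM to 100000 nM.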

Compound 4, half-maximal effective concentration: > 26000 nM
Compound 4 gave a limit, no number (the forecaster's own chance of this, stated with the estimate: 80%); the middle value lies beyond the limit too.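

Compound 4 again gives only a limit in this assay, > 26000 nM, so its steps to compound 1, compound 2 and compound 3 cannot be read. The compounds shown leave open whether any of these groups changes the half-maximal effective concentration in this assay.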